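The compounds below may be only part of what the source reports. "The series", "measured", "known", "first", "only" and "open" are said of these compounds alone.

Compound 1 `CCC1(Cc2ccccc2)OS(=O)(=O)C=C1OCCCCc1ccccc1`: in an ADME assay on HEL cells (Homo sapiens) for cytotoxicity, with a stated time of 3 days (a lower number here means that less compound is tolerated, a higher number that more compound is tolerated), compound 1 gives >= 20000 nM, which is a limit of the assay rather than a number.
Compound 2 `CCC1(Cc2ccccc2)OS(=O)(=O)C=C1OCc1ccc([N+](=O)[O-])cc1`: in this assay compound 2 gives >= 80000 nM, again a limit.
Compound 3 `CCC1(Cc2ccccc2)OS(=O)(=O)C=C1OCc1ccc(C(C)(C)C)cc1`: in this assay compound 3 gives >= 400000 nM, also a limit.

All three share one core and differ only in one side group on it. Compound 3 stands at the limit of >= 400000 nM in this assay, at which 1 of the 3 values shown sits, so for it only a limit is known, and the other two values are limits as well. The step that the two limits leave unreadable from compound 1 to compound 2 and the step that the two limits leave unreadable from compound 2 to compound 3 cannot be given a size or a direction.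

Compound 4 `CCC1(Cc2ccccc2)OS(=O)(=O)C=C1OCc1ccc(C)cc1` is the next member: methyl in place of tert-butyl on an aromatic carbon. For the measured compounds named here, the only measured step that bears on this change is a step that the two limits leave unreadable from compound 2 to compound 3, which touched the same aromatic carbon and stayed unreadable between two limits. With no readable step in hand, no change beyond the scatter is expected in this assay from compound 3 to compound 4, and another limit seems the most likely outcome. Compound 4 is expected to give about 200000 nM, in a range from 50000 nM to 500000 nM. This corresponds to an expected step of an at least 2.0-fold lower number from compound 3 to compound 4 (0.30 log units; that floor lies within the scatter).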

Compound 4, minimum cytotoxic concentration: >= 16000 nM
Compound 4 ended at the assay's limit; the forecaster's own chance of this, stated with the estimate: 80%; the middle value is on the limit's open side.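

Compound 4 also gives only a limit in this assay, like compound 1, compound 2 and compound 3, so its steps to those three compounds cannot be read. The compounds shown leave open whether changing the side group shifts the tolerated concentration at all, and in which direction.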